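The compounds below may be only part of what the source reports. "The series", "measured", "known", "first", "only" and "open" are said of these compounds alone.

Among the compounds with values here, in a functional assay for inhibition, with Homo sapiens as the target (a higher number here means that more compound is needed for the effect, a lower number that less compound is needed), compound 2 `CC(C)(CCl)C(=O)Nc1ccc(C2=NNC(=O)CC2)cc1` gives 11.4 ug/mL, the higher of the two numbers so far, while compound 1 `CCCC(=O)Nc1ccc(C2=NNC(=O)CC2)cc1` gives 1.44 ug/mL. Compound 3 `CC(C)NCC(=O)Nc1ccc(C2=NNC(=O)CC2)cc1` keeps the shared core but carries (isopropylamino)methyl in place of 1-(chloromethyl)-1-methylethyl on a carbonyl carbon. Within the data shown here, the only measured step at that place is a 7.9-fold higher number from compound 1 to compound 2 (0.90 log units; beyond the scatter), a modest change. With the group of compound 2 gone, a partial return toward compound 1 at 1.44 ug/mL is expected, meaning a smaller step towards a lower number in this assay. The expected change is a 2.3-fold lower number from compound 2 to compound 3 (0.36 log units; beyond the scatter). For compound 3 the estimated value is 5 ug/mL, with an expected range of 1.2 ug/mL to 20 ug/mL.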

Compound 3, half-maximal effective concentration: about 46.4 ug/mL
Beside the measured number, compound 3's estimate is 9.3-fold (0.97 log units) below it; measured number above the stated range.
By their numbers in this assay, from the lowest: compound 1; then compound 2; then compound 3.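

In this assay the change from 1-(chloromethyl)-1-methylethyl to (isopropylamino)methyl does not move back toward compound 1 but further from it, with a 4.1-fold higher number from compound 2 to compound 3 (0.61 log units; beyond the scatter) and a 32-fold higher number from compound 1 to compound 3 (1.51 log units; beyond the scatter) as the steps. At this place on a carbonyl carbon, both groups that replace propyl therefore raise the number, and the nitrogen-bearing group raises it more. Nothing measured here accounts for this difference. Still open, on these data alone, is whether a longer chain such as pentyl would give a lower number than propyl, and whether a smaller amine such as methylamino would behave like isopropylamino.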